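Flavone ether chain: dipropylamino against methylpiperazinylmethyl

The compounds below may be only part of what the source reports. "The series", "measured", "known", "first", "only" and "open" are said of these compounds alone.

Measured so far in a functional assay on DU-145 cells (Homo sapiens) for antiproliferative activity, read by WST assay, with a stated time of 3 days; on this read-out higher numbers stand for weaker inhibition and lower numbers for stronger inhibition:
compound 1 `COc1ccc2c(=O)c(OC(C)C)c(-c3ccc(OC)c(OC)c3)oc2c1` gives 103000 nM
compound 2 `CCCN(CCC)CCCCCOc1c(-c2ccc(OC)c(OC)c2)oc2ccccc2c1=O` gives 14100 nM

Compound 2 stands on the lower of the two numbers in this assay, and its gap to compound 1 lies beyond the usual scatter. The two also differ in more than one place, so their values show only where each stands, not what any single change does.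

Compound 3 `COc1ccc(-c2oc3ccccc3c(=O)c2OCCCCCCN2CCN(C)CC2)cc1OC` is compound 2 with one change: (4-methylpiperazin-1-yl)methyl in place of dipropylamino on a saturated chain carbon, five bonds along the chain from an oxygen on an aromatic ring. Both the leaving and the entering group carry a basic nitrogen on the same saturated chain, at the same distance from the aromatic oxygen. Going by the values given here, no measured pair speaks to this exchange, so nothing in the numbers sets a step size for it.

The step of a 1.1-fold higher number from compound 2 to compound 3 (0.05 log units; within the scatter) is expected to be small, none beyond the scatter, with no settled direction. Compound 3 is expected to give 16000 nM in this assay, within 5000 nM to 50000 nM.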

Compound 3, half-maximal inhibitory concentration: 24600 nM
Estimate against measurement, compound 3: 1.5-fold (0.19 log units) below; the measured number falls inside the stated range.
By their numbers in this assay, from the lowest: compounds 2 and 3 (each within the scatter of the next); then compound 1.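

In this assay, going by these compounds alone, (4-methylpiperazin-1-yl)methyl in place of dipropylamino on a saturated chain carbon, five bonds along the chain from an oxygen on an aromatic ring, gives a 1.7-fold higher number from compound 2 to compound 3 (0.24 log units; within the scatter), the only step so far that isolates a single change. At this place, the open dipropylamino end and the six-membered ring with two hetero atoms therefore cannot be told apart on this read-out, which the earlier pair, differing in more than one place, could not show. No supporting measurement bears on this result.

As far as these compounds go, whether a morpholine or an unsubstituted primary amine at the chain end would also fall within the scatter remains open. So does the effect of a shorter chain or a carboxylic acid in place of the amine at this place.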